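Flipping one stereocentre in a rice whole-organism assay

A few compounds are considered here, and "the series" means these few. Any claim that something is new, unique, unknown or untested is made for them only; others in the source may bear on it.

Three ureas have been measured so far. Compound 1 `C[C@H](NC(=O)Nc1cccc(C(F)(F)F)c1)c1ccccc1`, compound 2 `C[C@H](NC(=O)Nc1cc(F)ccc1F)c1ccccc1` and compound 3 `C[C@@H](NC(=O)Nc1cc(C(F)(F)F)ccc1F)c1ccccc1` share a common core and differ in the substituents on one aromatic ring. In an ADME assay on the whole organism with Oryza sativa as the target, tested at 10 uM (a higher number here means a weaker effect of the compound at the concentration tested, a lower number a stronger effect), compound 1 gives 92%, compound 2 gives 99% and compound 3 gives 60%. Compound 3 therefore stands lowest of the three, that is, it shows the strongest effect; its gap to compound 1 and its larger gap to compound 2 both lie beyond the scatter of the measurement.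

The next compound, compound 4 `C[C@H](NC(=O)Nc1cc(C(F)(F)F)ccc1F)c1ccccc1`, keeps every atom and bond of compound 3 and changes only the configuration at one centre: the two compounds have the same atoms and bonds and differ only in configuration as drawn: 1 of 1 stereo elements differ; a stereocentre at a saturated chain carbon is drawn R in compound 3 and S in compound 4. Among the measured compounds shown here, no pair among the measured compounds differs in configuration alone, so there is no measured step that would show how large such a change can be in this assay. The two drawn forms may behave alike or quite differently. Because compound 3 sits at 60%, a move away from it can only go upwards by much, and a moderate weakening of the effect is expected, giving an estimated step of a number 22 percentage points higher from compound 3 to compound 4 (beyond the scatter). For compound 4 the expected value in this assay is 82%, with a range from 55% to 100%.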

Compound 4, a percentage reported as activity, at one concentration (the size of the read-out at that concentration, not a potency): 87%
The estimate for compound 4 lay 5 percentage points below the measured number, within the range that was stated.
By their numbers in this assay, from the lowest: compound 3; then compounds 4, 1 and 2 (each within the scatter of the next, the first and the last beyond it).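

Configuration at this one chain carbon turns out to count in this assay, where the assay gives a number 27 percentage points higher from compound 3 to compound 4 (beyond the scatter), and this difference can be assigned to the stereocentre alone because nothing else separates the pair: the fact that compounds 3 and 4 differ only in the configuration as drawn

With the configuration of compound 4 held, the ring can be read on its own: trifluoromethyl in place of fluoro on an aromatic carbon gives a number 12 percentage points lower from compound 2 to compound 4 (beyond the scatter), and fluoro in place of hydrogen on an aromatic carbon gives a number 5 percentage points lower from compound 1 to compound 4 (within the scatter), a step too small to read as a real change. The ring pattern shared by compound 3 and compound 4 is therefore not enough by itself to give the stronger effect of compound 3, which appears only with the stereocentre drawn R.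

Going by these compounds, whether drawing the stereocentre R would also lower the numbers for the ring patterns of compound 1 and compound 2 remains open. So does what would happen with an ethyl group in place of the methyl at the stereocentre, or with a nitrile in place of the trifluoromethyl on the ring.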